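Swapping the Dichlorophenyl Arm for a Trifluoromethylphenyl

A few compounds are considered here, and "the series" means these few. Any claim that something is new, unique, unknown or untested is made for them only; others in the source may bear on it.

Of the compounds shown here, two from this series have been measured in a functional assay on BGC-823 cells (Homo sapiens) for antiproliferative activity, read by MTT assay, tested at 5 uM; on this read-out higher numbers stand for a stronger effect at the one concentration tested and lower numbers for a weaker effect. Compound 1 `COc1cc(C2=NN(C(C)=O)C(c3c(Cl)cccc3Cl)O2)cc(OC)c1OC` gives 15.9% in this assay. Compound 2 `COc1cccc(/C=N/NC(=O)c2cc(OC)c(OC)c(OC)c2)c1OC` gives 14.2% in this assay. Of the two numbers shown, compound 1 has the larger, but the gap to compound 2 lies within the usual scatter, so the two cannot be told apart on this read-out, and both stand at the weak end of what such a measurement can show.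

Compound 3 `COc1cc(C2=NN(C(C)=O)C(c3cccc(C(F)(F)F)c3)O2)cc(OC)c1OC` has not yet been measured. It differs from compound 1 in one place: 3-(trifluoromethyl)phenyl in place of 2,6-dichlorophenyl on a saturated ring carbon. Within the data shown here, no step between two measured compounds covers such a change, so there is nothing in the numbers that points to a direction, and the expected step is none beyond the scatter.

Compound 3 is therefore expected to give about 15% in this assay, with a range from 5% to 30%. The estimated step of a number 0.9 percentage points lower from compound 1 to compound 3 (within the scatter) is expected to stay within the scatter.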

Compound 3, a percentage reported as inhibition, at one concentration (the size of the read-out at that concentration, not a potency): 41.1%
Beside the measured number, compound 3's estimate is 26.1 percentage points below it; the measured number lies above the stated range.
By their numbers in this assay, from the lowest: compounds 2 and 1 (each within the scatter of the next); then compound 3.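

In this assay, among these compounds, placing 3-(trifluoromethyl)phenyl instead of 2,6-dichlorophenyl on the saturated ring carbon gives a number 25.2 percentage points higher from compound 1 to compound 3 (beyond the scatter) and so supplies the one step in this small set that can be read beyond the usual noise. It shows that this ring carbon, next to the ring oxygen and next to the ring nitrogen, is a place where the read-out responds to the choice of aryl group, even with the rest of the core of compound 1 unchanged. Nothing measured here bears on why this exchange moves the number.

The single swap removes both chlorines and brings in a trifluoromethyl group at once, so the compounds shown cannot tell whether the gain follows the loss of the chlorines, the arrival of the trifluoromethyl group, or both. Also open, going by these compounds, is how a plain phenyl, a methoxyphenyl or a dimethylaminophenyl group would fare at this carbon, whether a propionyl group could stand in for the acetyl group, and what potency lies behind a reading taken at one concentration.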